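A few compounds are considered here, and "the series" means these few. Any claim that something is new, unique, unknown or untested is made for them only; others in the source may bear on it.

Compound 1 `NS(=O)(=O)NCC1CCN(c2cc(-c3ccc(Cl)cc3)ncn2)CC1`: in a functional assay on HT-29 cells (Homo sapiens) for antiproliferative activity, read by sulforhodamine B assay, with a stated time of 48 h (a higher number here means a weaker inhibitor of growth, a lower number a stronger inhibitor of growth), compound 1 gives 37700 nM.
Compound 2 `COC(=O)c1ccc(-c2cc(N3CCC(CNS(N)(=O)=O)CC3)ncn2)cc1`: in this assay compound 2 gives 22900 nM.

Of these two numbers compound 1 carries the highest; its nearest neighbour is compound 2, and the step of a 1.6-fold lower number from compound 1 to compound 2 (0.22 log units; within the scatter) lies within the scatter. That step, methoxycarbonyl in place of chloro on an aromatic carbon, is the only measured one in this set. Compound 3 `NS(=O)(=O)NCCC1CCN(c2cc(-c3ccc(Cl)cc3)ncn2)CC1` differs from compound 1 in (sulfamoylamino)methyl in place of sulfamoylamino on a saturated chain carbon bound to a saturated ring carbon. For the measured compounds named here, no measured pair changes this saturated chain, so the data hold nothing that bears directly on the step from compound 1 to compound 3; the single step that does exist left the number within the scatter. The expectation is therefore a number close to that of compound 1: compound 3 is expected at 37700 nM, with a range from 15000 nM to 95000 nM. The step of no change at the digits printed from compound 1 to compound 3 (within the scatter) is estimated to be none beyond the scatter.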

Compound 3, concentration for 50% growth inhibition: 30500 nM
Compound 3: the middle estimate sits 1.2-fold (0.09 log units) above what was measured, within the range that was stated.
By their numbers in this assay, from the lowest: compounds 2, 3 and 1 (each within the scatter of the next).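

For the compounds shown here, compound 3 gives the first measured change on this saturated chain: going from (sulfamoylamino)methyl to 2-(sulfamoylamino)ethyl in this assay gives a 1.2-fold lower number from compound 1 to compound 3 (0.09 log units; within the scatter). At this place, then, the two chain lengths cannot be told apart by growth inhibition, just as chloro and methoxycarbonyl could not be told apart on the aromatic carbon. The data offer no measured property that could account for this result.

The compounds shown leave open whether a still longer chain carrying the sulfamoylamino group would also stay within the scatter of compound 1. They also leave open whether an amine or a carboxylic acid in place of the sulfamoylamino group would move the number at all, since that group is present in all three compounds.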